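Moving a methyl around a benzyl ring

The source may hold more compounds than are shown below. What is called first, only, known or untested is meant among the compounds shown, and "the series" means these compounds.

Compound 2 `COc1cccc(OC)c1OCCNCCOc1ccccc1OCc1cccc(C)c1`, 8.85
Compound 1 `COc1cccc(OC)c1OCCNCCOc1ccccc1OCc1ccccc1`, 9.37

In a functional assay on thoracic aorta for antagonist activity at Alpha-1D adrenergic receptor (Rattus norvegicus) (a higher number here means a more potent compound, by a factor of ten per unit of this negative logarithm, a lower number a less potent compound), compound 2 holds the lower of the two values, with compound 1 giving the higher. Going by the values given here, the one measured step, a number 0.52 log units lower from compound 1 to compound 2 (beyond the scatter), tells how a methyl placed on the benzyl ring changes the number. Compound 3 `COc1cccc(OC)c1OCCNCCOc1ccccc1OCc1ccc(C)cc1` keeps that methyl but shifts it: 4-methylphenyl in place of 3-methylphenyl on a saturated chain carbon bound to an oxygen on an aromatic ring. Among the compounds with values here, no measured step shows the effect of such a shift, so compound 3 is expected to stay near compound 2, with a step of about a number 0.05 log units lower from compound 2 to compound 3 (within the scatter) and an estimate of 8.8, between 8.2 and 9.4.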

Compound 3, negative logarithm of the antagonist equilibrium constant: 9.12
Estimate against measurement, compound 3: 0.32 log units below; the measured number falls inside the stated range.
By their numbers in this assay, from the lowest: compounds 2, 3 and 1 (each within the scatter of the next, the first and the last beyond it).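

Swapping 3-methylphenyl for 4-methylphenyl gives a number 0.27 log units higher from compound 2 to compound 3 (within the scatter), so this assay does not separate these two placements of the methyl. Adding the methyl as 4-methylphenyl gives a number 0.25 log units lower from compound 1 to compound 3 (within the scatter), so only the 3-methylphenyl of compound 2 stands clearly apart from the unsubstituted ring of compound 1. No available evidence explains this result. As far as these compounds go, whether a larger group such as ethyl or methoxy, or a chlorine atom, would stay as close to compound 1 on the benzyl ring remains open.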